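The source may hold more compounds than are shown below. What is called first, only, known or untested is meant among the compounds shown, and "the series" means these compounds.

Measured so far:
compound 1 `C/N=C(/NC#N)NCCCCCn1nc(-c2ccccc2)ccc1=O` — 100 mg/kg
compound 2 `CCC/N=C(/NC#N)NCCCCCn1nc(-c2ccccc2)ccc1=O` — > 100 mg/kg
compound 3 `CN(C)/C(=N/CCCCCn1nc(-c2ccccc2)ccc1=O)NC#N` — 81.5 mg/kg

In a functional assay on the whole organism (stomach) with Rattus norvegicus as the target (a lower number here means that less compound is needed, a higher number that more compound is needed for the effect), compound 1 gives 100 mg/kg, the higher of the two numbers present; compound 3 is nearest, with a 1.2-fold lower number from compound 1 to compound 3 (0.09 log units; within the scatter). For compound 2 only a limit is reported, (the limit of > 100 mg/kg in this assay, at which 1 of the 3 values shown sits). Compound 4 `CC(C)C/N=C(\S)NCCCCn1nc(-c2ccccc2)ccc1=O` has not been measured. Relative to compound 1 it shows (a group of 8 heavy atoms (5 carbon, 2 nitrogen, 1 sulfur; no ring) in place of a group of 8 heavy atoms (4 carbon, 4 nitrogen; no ring), on a saturated chain carbon, four bonds along the chain from an aromatic nitrogen). The measured steps alter only the chain end and are small: a number no lower from compound 1 to compound 2 (the limit leaves the size open) and a 1.2-fold lower number from compound 1 to compound 3 (0.09 log units; within the scatter), neither beyond the scatter, so they point in no direction for the change to compound 4. The expected step is therefore a 1.1-fold lower number from compound 1 to compound 4 (0.05 log units; within the scatter), with a wide range. Compound 4 is estimated at 90 mg/kg, between 30 mg/kg and 300 mg/kg.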

Compound 4, dose for half-maximal effect: > 100 mg/kg
Compound 4: no number, only a limit; the forecaster's own chance of this, stated with the estimate: 35%; middle value at least 1.1-fold (0.04 log units) away from the limit.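

In this assay compound 4 gives > 100 mg/kg, which is a limit and not a number. Among the compounds shown here, the step is a number no lower from compound 1 to compound 4 (the limit leaves the size open) and cannot be read in size; it shows only that the group of 8 heavy atoms (5 carbon, 2 nitrogen, 1 sulfur; no ring), on a saturated chain carbon, four bonds along the chain from an aromatic nitrogen, brings no lower number. The limit now covers a larger share of the series: the limit of > 100 mg/kg in this assay, at which 2 of the 4 values shown sit.

Open, as far as these compounds go, are the size of this step and whether an amine or a carboxylic acid at this place would give a readable number.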